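Propylsulfanyl for amino on the diphosphate core

The compounds below may be only part of what the source reports. "The series", "measured", "known", "first", "only" and "open" are said of these compounds alone.

Measured so far in an in vitro functional assay on 1321-N1 cells for agonist activity at P2Y purinoceptor 2 (Homo sapiens), read by scintillation proximity assay and inositol phosphate accumulation; on this read-out lower numbers stand for an effect already at smaller amounts and higher numbers for an effect only at larger amounts of compound:
compound 1 `Nc1nc(=O)ccn1[C@@H]1O[C@H](COP(=O)(O)OP(=O)(O)O)[C@@H](O)[C@H]1O` gives 604 nM.
compound 2 `Nc1nc(=O)ccn1[C@@H]1O[C@H](COP(=O)(O)O)[C@@H](O)[C@H]1O` gives only > 100000 nM, a limit of the assay and not a number.
compound 3 `O=c1ccn([C@@H]2O[C@H](COP(=O)(O)O)[C@@H](O)[C@H]2O)c(SCCc2ccccc2)n1` gives 1300 nM.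

Compound 1 holds the lowest of the two numbers in this assay; compound 3 is the nearest, with a higher number beyond the scatter, and the third value is the limit.

Compound 4 `CCCSc1nc(=O)ccn1[C@@H]1O[C@H](COP(=O)(O)OP(=O)(O)O)[C@@H](O)[C@H]1O` is not yet measured. It differs from compound 1 in one place: propylsulfanyl in place of amino on an aromatic carbon.

Among the measured compounds shown here, two measured steps bear on it. Removal of the terminal phosphate gave an at least 160-fold higher number from compound 1 to compound 2 (2.21 log units; beyond the scatter), with compound 2 sitting at the limit of > 100000 nM in this assay, at which 1 of the 3 values shown sits. On that monophosphate core, exchanging amino for a thioether gave an at least 76-fold lower number from compound 2 to compound 3 (1.88 log units; beyond the scatter); since compound 2 is a limit, this is itself a lower bound. The thioether in compound 4 is the shorter propylsulfanyl, and it sits on the diphosphate core of compound 1 rather than on a monophosphate, so the measured step is an analogy, not the same change.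

A lowering beyond the scatter is expected, a 6.0-fold lower number from compound 1 to compound 4 (0.78 log units; beyond the scatter), smaller than what compound 2 to compound 3 showed. For compound 4 the estimate in this assay is 100 nM, within 20 nM to 600 nM.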

Compound 4, half-maximal effective concentration: 1200 nM
Compound 4: the middle estimate sits 12-fold (1.08 log units) below what was measured, and the stated range ends below it.
By their numbers in this assay, from the lowest: compounds 1, 4 and 3 (each within the scatter of the next, the first and the last beyond it). At a limit, above all of these: compound 2.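

In this assay, the aromatic carbon between two ring nitrogen atoms accepts propylsulfanyl in place of amino on the core of compound 1, with a 2.0-fold higher number from compound 1 to compound 4 (0.30 log units; within the scatter), so the hydrogen-bond donor of the amino group is not needed for a value in this range. Among the compounds shown here, the large shift seen for a thioether on the monophosphate core, an at least 76-fold lower number from compound 2 to compound 3 (1.88 log units; beyond the scatter), has no counterpart on the diphosphate core, so that step does not transfer from one core to the other. Compound 2, the starting point of that step, stands at a limit and not a number: the limit of > 100000 nM in this assay, at which 1 of the 4 values shown sits.

Still open, going by these compounds, is how the same exchange depends on the chain: whether phenethylsulfanyl, the shorter methylsulfanyl or a longer alkylsulfanyl chain on the core of compound 1 would read apart from propylsulfanyl beyond the scatter. Also open, on these data alone, is whether the sulfur itself matters, which a propylamino or propoxy group at this carbon would help to settle.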